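Adding Fluorine to the Fused Ring of Compound 3

The source may report more compounds than this note shows. Statements on the series, on what has been measured and on what is new or still open speak of the compounds shown alone.

Compound 1, `NS(=O)(=O)c1ccc(Nc2ncc(F)c(Nc3nc4ccccc4s3)n2)cc1`, gives 22600 nM in a functional assay on MDA-MB-231 cells (Homo sapiens) for antiproliferative activity, read by MTT assay, with a stated time of 48 h; a higher number here means a weaker inhibitor, a lower number a stronger inhibitor.
Compound 2, `Cc1cnc(Nc2ccc([N+](=O)[O-])cc2)nc1Nc1nc2ccccc2s1`, gives 22500 nM in this assay.
Compound 3, `Cc1cnc(Nc2ccc(S(N)(=O)=O)cc2)nc1Nc1nc2ccccc2s1`, gives 16800 nM in this assay.

The three measured compounds share one core and sit close together. Compound 3 holds the lowest of the three numbers, yet both of its neighbours lie within the scatter of it: a 1.3-fold lower number from compound 1 to compound 3 (0.13 log units; within the scatter), and a 1.3-fold lower number from compound 2 to compound 3 (0.13 log units; within the scatter). Nothing here separates the three compounds beyond the noise of repeated measurement.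

Compound 4, `Cc1cnc(Nc2ccc(S(N)(=O)=O)cc2)nc1Nc1nc2ccc(F)cc2s1`, differs from compound 3 in one place: fluoro in place of hydrogen on an aromatic carbon. Going by the values given here, no measured step touches this position. The step from compound 1 to compound 3 exchanged a fluoro on the central part of the core, the step from compound 2 to compound 3 exchanged a group on the outer aromatic carbon, and both stayed within the scatter. On that basis compound 4 is expected to stay in the same region as compound 3, with no step beyond the scatter in either direction, which is the meaning of the expected step of a 1.1-fold lower number from compound 3 to compound 4 (0.02 log units; within the scatter). The estimate for compound 4 in this assay is therefore 16000 nM, with a range from 7000 nM to 36000 nM.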

Compound 4, half-maximal inhibitory concentration: 7580 nM
For compound 4 the middle estimate is 2.1-fold (0.32 log units) above the measured one; the range from low to high includes it.
By their numbers in this assay, from the lowest: compound 4; then compounds 3, 2 and 1 (each within the scatter of the next).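

Among the single changes shown, only the exchange of hydrogen for fluoro on this six-membered aromatic ring of carbon, part of a fused system of two rings, moves the number in this assay beyond the scatter (a 2.2-fold lower number from compound 3 to compound 4 (0.35 log units; beyond the scatter)). The earlier steps touched only the central part of the core and the outer aromatic carbon, so this fused part is the one place shown where a single fluorine atom separates two compounds, although the step is modest. No measurement given here bears on why the number moves at this position, so the step stands as an observation only.

On these data alone, it remains open whether the step belongs to fluoro itself or whether chloro, methoxy or an amine on the same carbon would shift the number as far, and whether other carbons of this ring would respond alike. As far as these compounds go, the fluoro also stands in only one setting, so its effect alongside the nitro group of compound 2, or alongside the fluoro on the central part of compound 1, remains open too.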